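Working notes: chloro for methyl on the anilide

A few compounds are considered here, and "the series" means these few. Any claim that something is new, unique, unknown or untested is made for them only; others in the source may bear on it.

Measured compounds in this series:
compound 1 `O=C(Cn1c(=O)c(/C=C\c2ccncc2)nc2ccccc21)Nc1ccc(F)cc1` — 59900 nM
compound 2 `O=C(COc1nc2ccccc2nc1/C=C\c1ccncc1)Nc1ccc(Cl)cc1` — > 100000 nM, a limit of the assay
compound 3 `Cc1ccc(C(=O)Nc2ccc(Cn3c(=O)c(C)nc4ccccc43)cc2)cc1` — > 100000 nM, a limit of the assay

In a functional assay on PC-3 cells (Homo sapiens) for inhibition, read by MTT assay, with a stated time of 24 h (on this read-out higher numbers stand for weaker inhibition and lower numbers for stronger inhibition), compound 1 gives 59900 nM. For compound 2 this assay returns only a limit, > 100000 nM. For compound 3 it likewise returns only a limit, > 100000 nM. Two of the three values therefore sit at the limit of > 100000 nM in this assay, at which 2 of the 3 values shown sit, and compound 3 stands among them: no numbered value is available that would place it against compound 1, only the knowledge that it did not reach half-maximal inhibition within the range tested.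

Compound 4 `Cc1nc2ccccc2n(Cc2ccc(NC(=O)c3ccc(Cl)cc3)cc2)c1=O` differs from compound 3 in a single place: chloro in place of methyl on an aromatic carbon. Going by the values given here, no step between measured compounds has been recorded for this change, so no measured size can be attached to it. The expectation is for no shift beyond the scatter in this assay, and compound 4 is expected to remain at the limit, the step of a number no higher from compound 3 to compound 4 (the limit leaves the size open) being taken as flat. Compound 4 is accordingly estimated at 100000 nM, within a range from 50000 nM to 200000 nM.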

Compound 4, half-maximal inhibitory concentration: 39600 nM
Beside the measured number, compound 4's estimate is 2.5-fold (0.40 log units) above it; measured number below the stated range.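

In this assay, going by these compounds alone, chloro in place of methyl on this aromatic carbon, para to a large group, gives the only readable step so far: an at least 2.5-fold lower number from compound 3 to compound 4 (0.40 log units; beyond the scatter). Compound 3 holds only a limit, > 100000 nM. The true size of the step therefore remains unknown, and the change shows only that this position can move a compound off the limit, because the starting point is censored: the limit of > 100000 nM in this assay, at which 2 of the 4 values shown sit.

As far as these compounds go, how a methoxy group or an amine on this aromatic carbon would read in this assay remains open, so the step cannot yet be tied to chloro in particular. From the compounds shown here alone, whether the 4-methylphenyl to 4-chlorophenyl change would act in the same direction on the core of compound 1 also remains open.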